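Methoxy for Methyl: Two Compounds at the Limit

The source may hold more compounds than are shown below. What is called first, only, known or untested is meant among the compounds shown, and "the series" means these compounds.

Compound 1 `Cc1ccc(-c2n[nH]cc2N2CCCNCC2)cc1` gives in an assay on isolated protein for binding affinity to 5-hydroxytryptamine receptor 1E (Homo sapiens) (on this read-out lower numbers stand for stronger inhibition and higher numbers for weaker inhibition), a value of > 10000 nM, which is a limit of the assay rather than a number.
Compound 2 `COc1cccc(-c2n[nH]cc2N2CCCNCC2)c1` gives in this assay > 10000 nM, again only a limit.

Compound 1 thus stands at the limit shown by the limit of > 10000 nM in this assay, at which 2 of the 2 values shown sit, sharing it with compound 2, so no measured step between them can be stated. Compound 3 `COc1ccc(-c2n[nH]cc2N2CCCNCC2)cc1` differs from compound 1 by methoxy in place of methyl on an aromatic carbon. Within the data shown here, no measured step guides this change, so any shift in this assay is expected to stay within the scatter, in no set direction. Compound 3 is therefore estimated at 15000 nM, ranging from 4000 nM to 60000 nM, most likely reported once more as a limit. The expected step from compound 1 to compound 3 is a step that the limit leaves unreadable from compound 1 to compound 3.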

Compound 3, inhibition constant: > 10000 nM
Compound 3: only a limit was reported; the forecaster's own chance of this, stated with the estimate: 85%; the middle value is on the limit's open side.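

Compound 1 and compound 3 both give only a limit, not a number, so no step from methyl to methoxy can be read: the limit of > 10000 nM in this assay, at which 3 of the 3 values shown sit.

The compounds shown leave open how strongly any of them binds and whether methoxy in place of methyl changes that at all.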